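A few compounds are considered here, and "the series" means these few. Any claim that something is new, unique, unknown or untested is made for them only; others in the source may bear on it.

Compound 1 `COc1ncnc2c1c(-c1ccoc1)cn2[C@@H]1O[C@H](CO)[C@@H](O)[C@H]1O` carries a furan-3-yl group on the core and, in a functional assay on A549 cells (Homo sapiens), read by MTT assay, with a stated time of 72 h (a lower number here means a stronger inhibitor, a higher number a weaker inhibitor), gives 1160 nM. For the measured compounds named here, of the two compounds measured so far it stands at the higher number, so it is the weaker inhibitor. Compound 2 `CSc1ncnc2c1c(-c1ccoc1)cn2[C@@H]1O[C@H](CO)[C@@H](O)[C@H]1O` gives 280 nM, and the step from compound 1 to compound 2 is a 4.1-fold lower number from compound 1 to compound 2 (0.62 log units; beyond the scatter).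

Compound 3 `COc1ncnc2c1c(-c1ccco1)cn2[C@@H]1O[C@H](CO)[C@@H](O)[C@H]1O` has not been measured. It differs from compound 1 by furan-2-yl in place of furan-3-yl on an aromatic carbon. Going by the values given here, the one measured step, from methoxy to methylsulfanyl, changes a different part of the molecule and therefore says nothing about what happens when the furan is attached through a different carbon. Among the compounds with values here, no measured pair shows the effect of furan-2-yl in place of furan-3-yl, so the direction of this step is open, and a change no larger than the scatter is the most reasonable starting point, with some room either way.

Compound 3 is therefore expected to give roughly 1400 nM, within a range of 450 nM to 4500 nM. The expected step of a 1.2-fold higher number from compound 1 to compound 3 (0.08 log units; within the scatter) reflects that uncertainty rather than any measured trend.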

Compound 3, half-maximal inhibitory concentration: 30 nM
For compound 3 the middle estimate is 47-fold (1.67 log units) above the measured one; measured number outside the range, below it.
By their numbers in this assay, from the lowest: compound 3; then compound 2; then compound 1.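

Attaching the furan through a different carbon gives a 39-fold lower number from compound 1 to compound 3 (1.59 log units; beyond the scatter) in this assay, a large step, whereas the earlier change on the other side of the core, a 4.1-fold lower number from compound 1 to compound 2 (0.62 log units; beyond the scatter), was modest. Furan-3-yl and furan-2-yl have the same atoms and the same counts of hydrogen-bond donors and acceptors, so this change lies only in how the furan is joined to the aromatic carbon of the core, and the result shows that the assay readout responds strongly to that connection even when the composition of the group stays the same. Nothing among the available data explains why this rearrangement has so large an effect.

The compounds shown leave open whether furan-2-yl would bring a similar step when methylsulfanyl replaces methoxy, since these two changes are seen only separately, each starting from compound 1. They also leave open whether this position depends on the furan itself or would accept another ring, such as thiophen-2-yl or phenyl, or a non-ring group such as an amine.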